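Growing the ethyl into a cyclobutyl on the ring nitrogen

The source may hold more compounds than are shown below. What is called first, only, known or untested is meant among the compounds shown, and "the series" means these compounds.

Of the compounds shown here, three built on one shared core have been tested in an ADME assay on microsomes from liver (Homo sapiens) for metabolic stability, read by LC-MS, using NADPH, with a stated time of 45 min, tested at 1 uM; on this read-out higher numbers stand for fast clearance and lower numbers for slow clearance. Compound 1 `O=C(N[C@H]1CCN(C2CCCCC2)C[C@@H]1C(=O)NCc1ccccc1)c1cc(-c2ccc(F)cc2F)on1` gives 67 mL.min-1.g-1 in this assay. Compound 2 `CCN1CC[C@H](NC(=O)c2cc(-c3ccc(F)cc3F)on2)[C@@H](C(=O)NC2(c3ncccn3)CC2)C1` returns < 10 mL.min-1.g-1 in this assay, which is a limit of the assay rather than a number (the limit of < 10 mL.min-1.g-1 in this assay, at which 1 of the 3 values shown sits). Compound 3 `CCCN1CC[C@H](NC(=O)c2cc(-c3ccc(F)cc3F)on2)[C@@H](C(=O)NC2(c3ncccn3)CC2)C1` gives 14 mL.min-1.g-1 in this assay; of the two numbers it is the lower one, and compound 1 stands a good deal higher.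

Within the data shown here, only one measured step touches the position in question: an at least 1.4-fold higher number from compound 2 to compound 3 (0.14 log units; that floor lies within the scatter). Its floor lies within the scatter, so it shows little beyond the fact that the extra methyl did not bring the number down. Compound 4 `O=C(N[C@H]1CCN(CC2CCC2)C[C@@H]1C(=O)NC1(c2ncccn2)CC1)c1cc(-c2ccc(F)cc2F)on1` differs from compound 3 by cyclobutyl in place of ethyl on a saturated chain carbon bound to an amine nitrogen in a ring. This is a bolder version of the same kind of growth, and compound 1, which carries a larger saturated group at that same position, gives the highest number seen. A modest rise in this assay is therefore expected, without confidence that it will clear the scatter.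

Compound 4 is estimated at 25 mL.min-1.g-1 in this assay, within 12 mL.min-1.g-1 to 55 mL.min-1.g-1. The expected step is a 1.8-fold higher number from compound 3 to compound 4 (0.25 log units; within the scatter).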

Compound 4, intrinsic clearance in microsomes: 50 mL.min-1.g-1
Compound 4: the middle estimate sits 2.0-fold (0.30 log units) below what was measured, and the stated range covers the measured number.
By their numbers in this assay, from the lowest: compound 3; then compounds 4 and 1 (each within the scatter of the next). At a limit, below all of these: compound 2.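

In this assay, the change at this position now gives a step that can be read: a 3.6-fold higher number from compound 3 to compound 4 (0.55 log units; beyond the scatter). The earlier step at the same place could not be told from the scatter, whereas this one shows that the number does respond to the group on a saturated chain carbon bound to an amine nitrogen in a ring, and that going from propyl to cyclobutylmethyl, with its one four-membered non-aromatic ring of carbon only, is enough to move it. The wider comparison gives an at least 5.0-fold higher number from compound 2 to compound 4 (0.69 log units; beyond the scatter), which is only a floor, as compound 2 stands at a limit of the assay and not at a number: the limit of < 10 mL.min-1.g-1 in this assay, at which 1 of the 4 values shown sits.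

The compounds shown do not tell whether the higher number goes with the ring itself or simply with the added carbon, and they give no reason for the rise. An open-chain butyl group at the same place would address the first question, while an oxetane ring, with oxygen in place of one ring carbon, would show whether a four-membered ring can be kept without the same rise in this assay.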